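The source may hold more compounds than are shown below. What is called first, only, known or untested is meant among the compounds shown, and "the series" means these compounds.

Compound 1 `ClCc1ccc(Cn2cnc3c(Cl)ncnc32)cc1` was tested in a functional assay on RXF 393 cells (Homo sapiens) for cytotoxicity, read by sulforhodamine B assay, with a stated time of 48 h; on this read-out higher numbers stand for weaker inhibition of growth and lower numbers for stronger inhibition of growth. In this assay compound 1 gives 5490 nM. Of the two numbers recorded, this is the highest. Its nearest neighbour is compound 2 `ClCc1cccc(Cn2cnc3c(Cl)nc(Cl)nc32)c1`, which gives 2090 nM in this assay, a lower number whose gap to compound 1 lies beyond the usual scatter of such measurements. Compound 3 `Nc1nc(Cl)c2ncn(Cc3ccccc3CCl)c2n1` is also part of the set, but in this assay compound 3 gives "not determined" (no result reported), so it offers no number to compare.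

Compound 4 `Nc1nc(Cl)c2ncn(Cc3ccc(CCl)cc3)c2n1` has not yet been measured. It differs from compound 1 in one place: amino in place of hydrogen on an aromatic carbon. Amino enters where hydrogen leaves, on an aromatic carbon of the shared core.

For the measured compounds named here, no pair of measured compounds shows this change, so the size of its effect cannot be read off the data. With nothing to anchor a shift, the step of a 1.1-fold lower number from compound 1 to compound 4 (0.04 log units; within the scatter) is expected to stay within the scatter. Compound 4 is therefore estimated to give 5000 nM in this assay, with an expected range from 1800 nM to 14000 nM.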

Compound 4, concentration for total growth inhibition: 7240 nM
Compound 4: the middle estimate sits 1.4-fold (0.16 log units) below what was measured; the range from low to high includes it.
By their numbers in this assay, from the lowest: compound 2; then compounds 1 and 4 (each within the scatter of the next).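

In this assay, for the compounds shown here, the step of a 1.3-fold higher number from compound 1 to compound 4 (0.12 log units; within the scatter) gives the first direct reading of a single change, which none of the earlier compounds offered. Amino in place of hydrogen, on an aromatic carbon between two ring nitrogen atoms of the shared core, leaves the number within the scatter, so compound 4 cannot be ranked against compound 1. No measurement shown here bears on what lies behind this result.

From the compounds shown here alone, whether a methylamino group, a hydroxyl group or a longer amine chain at this same place would also stay within the scatter remains open. The compounds shown also leave open whether amino would give a similar step on a core carrying other groups, since this single pair speaks only for the core of compound 1.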